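Adding a Methyl to Compound 1

The source may hold more compounds than are shown below. What is called first, only, known or untested is meant among the compounds shown, and "the series" means these compounds.

In a functional assay on A549 cells (Homo sapiens) for antiproliferative activity, read by sulforhodamine B assay, with a stated time of 48 h (on this read-out lower numbers stand for stronger inhibition and higher numbers for weaker inhibition), compound 1 `COc1ccc(C(=O)/C=C\Nc2ccc(-c3nc4cc(OC)c(OC)c(OC)c4s3)cc2)cc1[N+](=O)[O-]` gives 21200 nM. Compound 2 `COc1ccc(C(=O)/C=C\Nc2ccc(-c3nc4cc(OC)c(OC)c(OC)c4s3)cc2)cc1F` gives 15500 nM in this assay, and compound 3 `COc1cc(C(=O)/C=C\Nc2ccc(-c3nc4cc(OC)c(OC)c(OC)c4s3)cc2)cc([N+](=O)[O-])c1OC` gives 11800 nM. The steps of a 1.4-fold lower number from compound 1 to compound 2 (0.14 log units; within the scatter) and a 1.8-fold lower number from compound 1 to compound 3 (0.25 log units; within the scatter) both fall within the scatter, so the three measured compounds cannot be separated on these numbers. Compound 4 `COc1ccc(C(=O)/C=C\Nc2ccc(-c3nc4cc(OC)c(OC)c(OC)c4s3)cc2C)cc1[N+](=O)[O-]` differs from compound 1 by methyl in place of hydrogen on an aromatic carbon. Within the data shown here, no measured pair shows this change: the two steps that start from compound 1 concern a fluoro in place of nitro and a methoxy in place of hydrogen, and neither moved the number beyond the scatter. The change to compound 4 is a single carbon with no donor or acceptor, and the measured series gives no sign that a change of this kind moves the number. The account therefore expects for compound 4 in this assay no step beyond the scatter, that is a step of a 1.1-fold lower number from compound 1 to compound 4 (0.05 log units; within the scatter). Compound 4 is thus estimated at 19000 nM, with the measured number expected to fall between 7000 nM and 50000 nM.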

Compound 4, half-maximal inhibitory concentration: 9100 nM
Compound 4: middle estimate off by 2.1-fold (0.32 log units), on the high side, and the stated range covers the measured number.
By their numbers in this assay, from the lowest: compounds 4, 3, 2 and 1 (each within the scatter of the next, the first and the last beyond it).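

In this assay, among these compounds, the change gives a 2.3-fold lower number from compound 1 to compound 4 (0.37 log units; beyond the scatter) and this modest step is the only one starting at compound 1 that lies beyond the scatter. It shows that this change, ortho to a large group and meta to a large group, can shift the number, whereas the changes elsewhere in the molecule, a 1.4-fold lower number from compound 1 to compound 2 (0.14 log units; within the scatter) and a 1.8-fold lower number from compound 1 to compound 3 (0.25 log units; within the scatter) did not do so beyond the scatter. No available evidence bears on why the number moved.

The compounds shown leave open whether an ethyl chain, an amine or a chlorine at this same carbon would move the number further, leave it in place or reverse the step. They also leave open whether the methyl would give a similar step on compound 2 or compound 3.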